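Three Inert Halogen Analogues and a Fourth to Come

This account rests on a few compounds, and the source may have more. Where it says the series, first, only, none or still open, it means among the compounds named here.

Compound 1, `Fc1ccc2[nH]c(-c3cn(-c4ccccc4)nc3-c3ccccc3)nc2c1`, in an ADME assay on HaCaT cells (Homo sapiens) for cytotoxicity, read by MTT assay, with a stated time of 48 h (a lower number here means a stronger inhibitor, a higher number a weaker inhibitor), gives > 50000 nM, which is a limit of the assay and not a number.
Compound 2, `Clc1ccc2[nH]c(-c3cn(-c4ccccc4)nc3-c3ccccc3)nc2c1`, in this assay gives > 50000 nM, again a limit of the assay.
Compound 3, `Fc1ccc2[nH]c(-c3cn(-c4ccccc4)nc3-c3ccc(Cl)cc3)nc2c1`, in this assay gives > 50000 nM, also a limit of the assay.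

All three measured values sit at the same boundary, the one described by the limit of > 50000 nM in this assay, at which 3 of the 3 values shown sit. The change from compound 1 to compound 2 is chloro in place of fluoro on an aromatic carbon, and its step in this assay is a step that the two limits leave unreadable from compound 1 to compound 2. The cores of compound 1 and compound 3 differ by chloro in place of hydrogen on an aromatic carbon, and that step in this assay is a step that the two limits leave unreadable from compound 1 to compound 3. Neither pair allows a size to be read, since both members of each pair rest on the limit.

Compound 4, `Clc1ccc(-c2nn(-c3ccccc3)cc2-c2nc3cc(Cl)ccc3[nH]2)cc1`, has not yet been measured in this assay. It differs from compound 3 by chloro in place of fluoro on an aromatic carbon. This is the same change as that from compound 1 to compound 2, made on a core that already carries the change described by chloro in place of hydrogen on an aromatic carbon. Compound 4 is expected to give a step that the limit leaves unreadable from compound 3 to compound 4 in this assay, because the earlier instance of this change produced a step that the two limits leave unreadable from compound 1 to compound 2 and because every value shown sits at the limit of > 50000 nM in this assay, at which 3 of the 3 values shown sit. Compound 4 is therefore estimated at 70000 nM in this assay, with the expectation that the assay again reports only a limit, between 30000 nM and 250000 nM.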

Compound 4, half-maximal inhibitory concentration: > 50000 nM
Compound 4 gave a limit, no number; the forecaster's own chance of this, stated with the estimate: 85%; the middle value lies beyond the limit too.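

Neither step to compound 4, from compound 3 or from compound 2, can be read, since both members of each pair rest on a limit of the assay: the limit of > 50000 nM in this assay, at which 4 of the 4 values shown sit.

The compounds shown leave open whether chloro in place of fluoro, or chloro in place of hydrogen, changes the reading in this assay at all; none of the four gives a number.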